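Bromine moved on the chalcone ring: compound 3 to compound 4

The source may hold more compounds than are shown below. What is called first, only, known or untested is meant among the compounds shown, and "the series" means these compounds.

Compound 1 `COC(=O)c1cc(-c2cccc(NC(=O)c3ccc(C4OC4C(=O)c4ccc(Cl)cc4)cc3)c2)on1`: > 20 ug/mL
Compound 2 `COC(=O)c1cc(-c2cccc(NC(=O)c3ccc(/C=C/C(=O)c4ccccc4OC)cc3)c2)on1`: > 40 ug/mL
Compound 3 `COC(=O)c1cc(-c2cccc(NC(=O)c3ccc(/C=C/C(=O)c4ccc(Br)cc4)cc3)c2)on1`: > 20 ug/mL

In an ADME assay on Vero cells (Chlorocebus sabaeus) for cytotoxicity, read by MTT assay, with a stated time of 72 h (on this read-out higher numbers stand for lower toxicity in this test and lower numbers for higher toxicity in this test), every value reported so far is a limit of the assay rather than a number. Compound 1 gives > 20 ug/mL, which is a limit. Compound 2 gives > 40 ug/mL, again a limit. Compound 3 gives > 20 ug/mL, also a limit, so compound 3 sits where two of the three values sit (the limit of > 20 ug/mL in this assay, at which 2 of the 3 values shown sit), with the remaining value at a higher limit (the limit of > 40 ug/mL in this assay, at which 1 of the 3 values shown sits). The steps a step that the two limits leave unreadable from compound 1 to compound 3 and a step that the two limits leave unreadable from compound 2 to compound 3 therefore carry no readable size.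

Compound 4 `COC(=O)c1cc(-c2cccc(NC(=O)c3ccc(/C=C/C(=O)c4cccc(Br)c4)cc3)c2)on1` differs from compound 3 only in that (3-bromophenyl in place of 4-bromophenyl on a carbonyl carbon). Among the measured compounds shown here, no measured step bears on this change with a readable size, and the step from compound 1 to compound 3 and the step from compound 2 to compound 3 are both unreadable between limits. No step beyond the scatter is expected in this assay, so compound 4 is expected to give 40 ug/mL (range 20 ug/mL to 80 ug/mL), corresponding to an expected step that the limit leaves unreadable from compound 3 to compound 4.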

Compound 4, half-maximal cytotoxic concentration: > 100 ug/mL
Compound 4 ended at the assay's limit; the forecaster's own chance of this, stated with the estimate: 85%; middle value at least 2.5-fold (0.39 log units) away from the limit.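

Compound 4, like compound 1, compound 2 and compound 3, is reported only as a limit, so none of the steps joining compound 4 to the other three can be read. The compounds shown leave open whether 3-bromophenyl in place of 4-bromophenyl changes the read-out in this assay at all.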